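Series notes: chloro to hydroxy on the aromatic ring

The source may report more compounds than this note shows. Statements on the series, on what has been measured and on what is new or still open speak of the compounds shown alone.

Compound 1 `O=C(N/N=C/c1cccc(Cl)c1)c1cnccn1` is read in an ADME assay on J774 cells (Mus musculus) for cytotoxicity, read by MTT assay, with a stated time of 48 h, tested at 100 ug/mL (on this read-out lower numbers stand for a stronger effect and higher numbers for a weaker effect at the one concentration tested), where compound 1 gives 100%. Compound 2 `O=C(N/N=C/c1ccc(Br)cc1)c1cnccn1` gives 100% in this assay, level with compound 1 as far as the numbers show, and together the two are the highest of the three values. Compound 3 `COc1ccc(/C=N/NC(=O)c2cnccn2)cc1` lies furthest from compound 1. In this assay compound 3 gives 55%. Among the compounds with values here, the single step among measured compounds that differ in one place is a number 45 percentage points lower from compound 2 to compound 3 (beyond the scatter), a large drop for methoxy in place of bromo on an aromatic carbon. Compound 4 `O=C(N/N=C/c1cccc(O)c1)c1cnccn1` differs from compound 1 by hydroxy in place of chloro on an aromatic carbon. Within the data shown here, this is again a halogen giving way to an oxygen-bearing group on an aromatic carbon, so the step from compound 2 to compound 3 is the only guide, although the entering group and its place are not the same. Among the measured compounds shown here, a lowering in this assay is expected for compound 4, of uncertain size because the only comparable step is a number 45 percentage points lower from compound 2 to compound 3 (beyond the scatter), and the estimated step is a number 30 percentage points lower from compound 1 to compound 4 (beyond the scatter). For compound 4 the expected value in this assay is 70%, with a range from 45% to 100%.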

Compound 4, a percentage reported as activity, at one concentration (the size of the read-out at that concentration, not a potency): 100%
Compound 4: the middle estimate sits 30 percentage points below what was measured; measured number inside the range.
By their numbers in this assay, from the lowest: compound 3; then compounds 1, 2 and 4 (each within the scatter of the next).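

In this assay, hydroxy in place of chloro on an aromatic carbon, meta to a large group, gives no change at the digits printed from compound 1 to compound 4 (within the scatter), so at this place an oxygen-bearing group can replace a halogen without any shift in the read-out. The lowering seen as a number 45 percentage points lower from compound 2 to compound 3 (beyond the scatter) therefore does not extend to every swap of a halogen for an oxygen-bearing group; it remains the only lowering among the steps shown, and it involves a different entering group at a different place. No measurement bears on why the two steps part, and the comparison stops at these numbers.

Still open, going by these compounds, is whether the lowering follows methoxy itself or its place on the ring, which methoxy at the place of chloro in compound 1 would separate. Also open, on these data alone, is how this place responds to an amine or a carboxylic acid.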